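Cyclopropyl in Place of Pyridin-2-yl on an Amide Nitrogen

This account rests on a few compounds, and the source may have more. Where it says the series, first, only, none or still open, it means among the compounds named here.

Of the compounds shown here, three have been tested in an assay on HEK293 cells for agonist activity at transient receptor potential cation channel subfamily M member 8 (Homo sapiens), read by fluorescence and calcium flux, with a stated time of 15 min; on this read-out higher numbers stand for an effect only at larger amounts of compound and lower numbers for an effect already at smaller amounts. Compound 1 `CCN(Cc1cccs1)C(=O)c1cc2cc(C)ccc2[nH]1` gives 2010 nM, compound 2 `Cc1ccc(OCC(=O)N(Cc2cccs2)c2ccccn2)cc1` gives 200 nM, and compound 3 `CCN(Cc1cccs1)C(=O)COc1ccc(OC)cc1` gives 120 nM. Among these, compound 2 holds the second highest number of the three: its nearest neighbour is compound 3, whose number is lower by an amount that stays within the scatter, while compound 1 sits far higher, beyond the scatter.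

The next compound, compound 4 `Cc1ccc(OCC(=O)N(Cc2cccs2)C2CC2)cc1`, keeps everything in compound 2 except one group: cyclopropyl in place of pyridin-2-yl on an amide-type nitrogen. Among the compounds with values here, no pair of measured compounds differs at exactly this position, so no measured step is available to guide the expectation directly. What can be said is that compound 3, which also carries a small saturated group on an amide-type nitrogen, gives 120 nM, a number within the scatter of compound 2. On that basis the step of a 1.3-fold lower number from compound 2 to compound 4 (0.10 log units; within the scatter) is expected to be small, with no change beyond the scatter in either direction. Compound 4 is therefore estimated at 160 nM in this assay, with a range from 50 nM to 500 nM.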

Compound 4, half-maximal effective concentration: 8 nM
For compound 4 the middle estimate is 20-fold (1.30 log units) above the measured one; the whole stated range lies above it.
By their numbers in this assay, from the lowest: compound 4; then compounds 3 and 2 (each within the scatter of the next); then compound 1.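

In this assay, this change gives the first step read at this position, and it is large: a 25-fold lower number from compound 2 to compound 4 (1.40 log units; beyond the scatter). With the rest of compound 2 left as it is, the group on this amide-type nitrogen therefore has a strong bearing on the amount of compound needed for an effect. The exchange alters several features at once, replacing a six-membered aromatic ring with 1 hetero atom and 1 hydrogen-bond acceptor with a three-membered non-aromatic ring of carbon only and 0 hydrogen-bond acceptors, and nothing available shows why the number moves so far.

A single step cannot separate ring size, aromatic character and the ring nitrogen from one another. Phenyl on the same nitrogen would keep a six-membered aromatic ring without that nitrogen, while cyclobutyl or isopropyl would stay saturated with a different shape, so whether each behaves more like pyridin-2-yl or more like cyclopropyl remains open.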